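The source may report more compounds than this note shows. Statements on the series, on what has been measured and on what is new or still open speak of the compounds shown alone.

Among the measured compounds shown here, in a functional assay on DU-145 cells (Homo sapiens) for inhibition, read by trypan blue exclusion, with a stated time of 72 h (on this read-out lower numbers stand for stronger inhibition and higher numbers for weaker inhibition), compound 1 `Cc1ccc(S(=O)(=O)c2cc3cnc(Nc4cnc5[nH]ccc5c4)nc3n(C)c2=O)cc1` gives 25000 nM, the highest of the three numbers so far and the weakest of the measured compounds. Compound 2 `Cn1c(=O)c(S(=O)(=O)c2ccc(F)cc2F)cc2cnc(Nc3cnc4[nH]ccc4c3)nc21` gives 750 nM, and compound 3 `Cn1c(=O)c(S(=O)(=O)c2ccc(F)cc2)cc2cnc(Nc3cnc4[nH]ccc4c3)nc21` gives 500 nM. The measured steps are a 33-fold lower number from compound 1 to compound 2 (1.52 log units; beyond the scatter) and a 50-fold lower number from compound 1 to compound 3 (1.70 log units; beyond the scatter), both large, whereas a 1.5-fold lower number from compound 2 to compound 3 (0.18 log units; within the scatter) stays within the scatter. All three concern only the group on the sulfonyl sulfur.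

Compound 4 `Cc1ccc(S(=O)(=O)c2cc3cnc(Nc4cccc5[nH]ccc45)nc3n(C)c2=O)cc1` keeps the 4-methylphenyl group of compound 1 and changes a different place: a group of 9 heavy atoms (8 carbon, 1 nitrogen; one five-membered aromatic ring with 1 hetero atom, one six-membered aromatic ring of carbon only) in place of a group of 9 heavy atoms (7 carbon, 2 nitrogen; one five-membered aromatic ring with 1 hetero atom, one six-membered aromatic ring with 1 hetero atom), on a nitrogen on an aromatic ring. For the measured compounds named here, no measured step touches this place, so the data give no direct size for the swap to 1H-indol-4-yl. Going by the values given here, the large steps show only that a single change elsewhere in this small set can move the number widely. With compound 1 at 25000 nM, the top of the measured numbers, a moderate fall in this assay is expected rather than a rise, although a result within the scatter of compound 1 would be unsurprising. The estimated change is a 3.1-fold lower number from compound 1 to compound 4 (0.49 log units; beyond the scatter), held with low confidence. For compound 4 the expected value is 8000 nM, with an estimated range of 1000 nM to 40000 nM.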

Compound 4, half-maximal inhibitory concentration: 10000 nM
Compound 4: middle estimate off by 1.3-fold (0.10 log units), on the low side; the range from low to high includes it.
By their numbers in this assay, from the lowest: compounds 3 and 2 (each within the scatter of the next); then compound 4; then compound 1.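

Among the compounds shown here, this is the first reading at the group on the nitrogen on an aromatic ring: in this assay, the swap to 1H-indol-4-yl gives a 2.5-fold lower number from compound 1 to compound 4 (0.40 log units; beyond the scatter), so the six-membered aromatic ring of carbon only, with 0 hydrogen-bond acceptors against 1 in the group that leaves, is tolerated with the 4-methylphenyl group on the sulfonyl sulfur and gives a modest gain. The position therefore responds, but this swap moves the number far less than the change on the sulfonyl sulfur, a 50-fold lower number from compound 1 to compound 3 (1.70 log units; beyond the scatter), which is printed as large. No measurement available here bears on the origin of the step at this nitrogen.

On these data alone, whether the 1H-indol-4-yl swap gives a step of similar size on the sulfonyl group of compound 2 or compound 3 stays open, so the two places cannot yet be judged as additive. Also open, as far as these compounds go, is how this position answers to a group carrying an amine or a carboxylic acid on the 1H-indol-4-yl ring system, and whether a simple phenyl at the same nitrogen would hold the number of compound 4.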